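The compounds below may be only part of what the source reports. "The series", "measured", "known", "first", "only" and "open" are said of these compounds alone.

Measured so far in an assay on CHO cells for binding affinity to Substance-P receptor (Homo sapiens); on this read-out lower numbers stand for stronger inhibition and higher numbers for weaker inhibition:
- compound 1 `CCCCCN(CCCCC)C(=O)N1CCN(C(=O)N(c2ccccc2)c2ccccc2)[C@H](C(=O)NCC(=O)O)C1` gives 597 nM
- compound 2 `CCCCCN(CCCCC)C(=O)N1CCN(C(=O)N(c2ccccc2)c2ccccc2)[C@H](C(=O)N(C)CCN(C)C)C1` gives 930 nM

For the measured compounds named here, compound 2 stands at the higher of the two numbers, with compound 1 as its only neighbour, and the step of a 1.6-fold higher number from compound 1 to compound 2 (0.19 log units; within the scatter) lies within the scatter, so the two compounds are not separated by the assay on this read-out.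

Compound 3 `CCCCCN(CCCCC)C(=O)N1CCN(C(=O)N(c2ccccc2)c2ccccc2)[C@H](C(=O)N(C)CCN(C)Cc2ccccc2)C1` carries the change phenyl in place of hydrogen on a saturated chain carbon bound to an amine nitrogen on the side chain of compound 2, so that the dimethylamino end becomes benzyl(methyl)amino.

Going by the values given here, no measured step covers this kind of change. Among the compounds with values here, the only step, from compound 1 to compound 2, swaps the whole side chain on the carbonyl carbon and stays within the scatter, which gives no lever for the direction of a further extension of the amine. With nothing pointing either way, the working expectation for compound 3 is a number near that of compound 2, with no step beyond the scatter.

The estimate for compound 3 is 900 nM, with a range from 300 nM to 3000 nM. This estimate amounts to a 1.0-fold lower number from compound 2 to compound 3 (0.01 log units; within the scatter), expected to remain inside the usual scatter.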

Compound 3, half-maximal inhibitory concentration: 290 nM
For compound 3 the middle estimate is 3.1-fold (0.49 log units) above the measured one; measured number outside the range, below it.
By their numbers in this assay, from the lowest: compound 3; then compounds 1 and 2 (each within the scatter of the next).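

In this assay, for the compounds shown here, the amine end of the side chain is the first place where a change moves the number beyond the scatter: phenyl in place of hydrogen on a saturated chain carbon bound to an amine nitrogen, which turns dimethylamino into benzyl(methyl)amino, gives a 3.2-fold lower number from compound 2 to compound 3 (0.51 log units; beyond the scatter). The step is modest, but it shows that this position responds to the added aromatic ring, whereas swapping the whole side chain on the carbonyl carbon, a 1.6-fold higher number from compound 1 to compound 2 (0.19 log units; within the scatter), did not separate its two compounds. Nothing measured here speaks to the origin of the step.

On these data alone, whether the lower number belongs to the aromatic ring itself or to any larger group at this position stays open, and a cyclohexylmethyl or a phenethyl group on the same amine nitrogen would separate those two readings. Also open, as far as these compounds go, is whether a substituent on the phenyl, such as a chlorine atom or a methoxy group, moves the number further in either direction.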